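The source may hold more compounds than are shown below. What is called first, only, known or untested is meant among the compounds shown, and "the series" means these compounds.

In a functional assay on BT-474 cells (Homo sapiens) for inhibition, read by fluorescence, with a stated time of 72 h (a lower number here means a stronger inhibitor of growth, a higher number a weaker inhibitor of growth), compound 1 (`COc1cc(Nc2nc(N[C@H]3CC[C@H](N)CC3)nc3c2ncn3CCC(C)C)cc(OC)c1`) gives 5900 nM and compound 2 (`CCCCCCn1cnc2c(Nc3cccc(Cl)c3)nc(N[C@H]3CC[C@H](N)CC3)nc21`) gives 5100 nM, so compound 2 stands level with compound 1 within the scatter. Compound 3 (`CC(C)CCn1cnc2c(Nc3cccc(Cl)c3)nc(N[C@H]3CC[C@H](N)CC3)nc21`) departs from compound 2 in one place: isopropyl in place of butyl on a saturated chain carbon, two bonds along the chain from an aromatic nitrogen. In this assay, among the compounds with values here, compound 2 gives 5100 nM, and no measured pair isolates this change, so compound 3 is expected to stay close to compound 2. The estimated change is a 1.1-fold higher number from compound 2 to compound 3 (0.03 log units; within the scatter). Compound 3 is expected at 5500 nM, within an estimated range of 2500 nM to 11000 nM.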

Compound 3, concentration for 50% growth inhibition: 3800 nM
Compound 3: the middle estimate sits 1.4-fold (0.16 log units) above what was measured, within the range that was stated.
By their numbers in this assay, from the lowest: compounds 3, 2 and 1 (each within the scatter of the next).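

In this assay, within the data shown here, the exchange of butyl for isopropyl, on a saturated chain carbon, two bonds along the chain from an aromatic nitrogen, gives a 1.3-fold lower number from compound 2 to compound 3 (0.13 log units; within the scatter) and is the first measured pair at this place. The exchange of 3,5-dimethoxyphenyl for 3-chlorophenyl on a nitrogen on an aromatic ring gives a 1.6-fold lower number from compound 1 to compound 3 (0.19 log units; within the scatter) and so leaves the number within the scatter at that place too. Nothing at hand accounts for either step.

As far as these compounds go, whether any group at the chain position can move the number beyond the scatter stays open. A terminal amine or a methyl group there, or a pyridine in place of the 3-chlorophenyl, would test this.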